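Swapping iodine for a hexyloxy chain on the sulfonamide aryl

The source may hold more compounds than are shown below. What is called first, only, known or untested is meant among the compounds shown, and "the series" means these compounds.

Of the compounds shown here, two sharing one core have been measured. Compound 1 `Cc1cccc(NS(=O)(=O)c2ccc(N3CCNC3=O)cc2)c1` gives 190 nM in a functional assay on MCF7 cells (Homo sapiens) for antiproliferative activity, read by sulforhodamine B assay, with a stated time of 48 h (on this read-out lower numbers stand for stronger inhibition and higher numbers for weaker inhibition), and compound 2 `O=C1NCCN1c1ccc(S(=O)(=O)Nc2ccc(I)cc2)cc1` gives 600 nM. Going by the values given here, compound 2 therefore holds the higher number of the two, and the only measured step, a 3.2-fold higher number from compound 1 to compound 2 (0.50 log units; beyond the scatter), shows that exchange of one aryl substituent for another on the sulfonamide nitrogen was enough to move the read-out.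

Compound 3 `CCCCCCOc1ccc(NS(=O)(=O)c2ccc(N3CCNC3=O)cc2)cc1` differs from compound 2 in a single place: hexyloxy in place of iodo on an aromatic carbon. Among the compounds with values here, no measured step touches this position with these groups, so the one step on record offers only a loose hint that changes on this part of the molecule matter, without telling the direction. For compound 3 a number close to that of compound 2 is therefore expected, the step of a 1.2-fold lower number from compound 2 to compound 3 (0.08 log units; within the scatter) lying within the usual scatter. The estimate for compound 3 is 500 nM, with a range from 150 nM to 2000 nM.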

Compound 3, half-maximal inhibitory concentration: > 1000 nM
Compound 3 was reported as a limit; the forecaster's own chance of this, stated with the estimate: 10%; middle value at least 2.0-fold (0.30 log units) from the limit.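

In this assay compound 3 is reported as a limit, > 1000 nM, and not as a number. Going by these compounds alone, exchanging iodo for hexyloxy on this aromatic carbon gives an at least 1.6-fold higher number from compound 2 to compound 3 (0.22 log units; that floor lies within the scatter), so the hexyloxy chain brings no lower number here, which the earlier compounds could not show, although only a floor is printed and the full size of the step stays unfixed. Among the compounds shown, this is the only value of its kind: the limit of > 1000 nM in this assay, at which 1 of the 3 values shown sits.

On these data alone, whether a short methoxy group, an amine or a carboxylic acid on this same carbon would give a number near that of compound 2 remains open. The compounds shown also cannot separate the effect of the oxygen from that of the chain, since an unbroken hexyl chain or a butoxy chain does not appear among them.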